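Compound 3 to compound 4: allyl to dodecyl

The compounds below may be only part of what the source reports. "The series", "measured", "known", "first", "only" and "open" are said of these compounds alone.

Within the data shown here, in an ADME assay on HII4E cells (Mus musculus) for cytotoxicity, read by MTT assay, with a stated time of 48 h (on this read-out higher numbers stand for weaker inhibition and lower numbers for stronger inhibition), the series so far holds three numbers. Compound 1 `CC(=O)OC[C@@H]1C=C(OC(C)=O)C(=O)[C@@H](OCC(=O)NCc2ccccc2)O1` gives 163 ug/mL and compound 2 `CCCCCCCCCCCCNC(=O)CO[C@@H]1O[C@H](COC(C)=O)C=C(OC(C)=O)C1=O` gives 45 ug/mL on this measure. Compound 3 `C=CCNC(=O)CO[C@H]1O[C@H](COC(C)=O)C=C(OC(C)=O)/C1=C\C(=O)OCC` gives 352 ug/mL as the highest of the three, with compound 1 the nearest and compound 2 the furthest, both gaps beyond the scatter.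

Compound 4 `CCCCCCCCCCCCNC(=O)CO[C@H]1O[C@H](COC(C)=O)C=C(OC(C)=O)/C1=C\C(=O)OCC` differs from compound 3 at one place: undecyl in place of vinyl on a saturated chain carbon bound to an amide-type nitrogen with undecyl in place of vinyl on a saturated chain carbon bound to an amide-type nitrogen, which also reads as allyl to dodecyl.

Among the measured compounds shown here, no measured pair shows this change directly. Compound 2 also carries a dodecyl, on a different core, and gives 45 ug/mL as its number. On that basis, a step to a lower number beyond the scatter is expected in this assay, with wide uncertainty. The expected size is a 3.9-fold lower number from compound 3 to compound 4 (0.59 log units; beyond the scatter) on this estimate. For compound 4 the estimated value is 90 ug/mL within an expected range of 30 ug/mL to 250 ug/mL in this assay.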

Compound 4, half-maximal inhibitory concentration: 76 ug/mL
Compound 4: the middle estimate sits 1.2-fold (0.07 log units) above what was measured, and the stated range covers the measured number.
By their numbers in this assay, from the lowest: compounds 2 and 4 (each within the scatter of the next); then compound 1; then compound 3.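

In this assay, among these compounds, the first direct reading at this position comes from a single change on the shared core: undecyl in place of vinyl on a saturated chain carbon bound to an amide-type nitrogen gives a 4.6-fold lower number from compound 3 to compound 4 (0.67 log units; beyond the scatter) as a modest step. The position is therefore not silent on this read-out, as the allyl to dodecyl change alone moves the number beyond the scatter, towards stronger inhibition. Nothing measured here accounts for this step.

On these data alone, with only two chains read on this core, the shape of the relation between chain and number stays open, and an octyl chain or a longer chain would help define it. A dodecyl chain ending in an amine or a carboxylic acid would show whether the chain alone carries the step.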